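The compounds below may be only part of what the source reports. "The series", "measured", "known", "first", "only" and "open" are said of these compounds alone.

Of the compounds shown here, three have so far been measured in a functional assay on HEp-2 cells (Homo sapiens) for cytotoxicity, read by MTT assay, with a stated time of 72 h; a lower number here means a stronger inhibitor, a higher number a weaker inhibitor. Compound 1 (`Cc1nnc(SCc2cc(=O)c3cc(Cl)ccc3o2)s1`) gives > 25000 nM, which is a limit of the assay rather than a number. Compound 2 (`Cc1nnc(SCc2cc(=O)c3ccccc3o2)s1`) gives > 25000 nM, again a limit. Within the data shown here, compound 3 (`Cc1nnc(SCc2coc3ccc(Cl)cc3c2=O)o1`) gives 6400 nM, the only actual number among the three, since the other two values sit at the limit of > 25000 nM in this assay, at which 2 of the 3 values shown sit. The step from compound 1 to compound 2, hydrogen in place of chloro on an aromatic carbon, is a step that the two limits leave unreadable from compound 1 to compound 2, so its size cannot be read.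

Compound 4 (`Cc1nnc(SCc2coc3ccccc3c2=O)o1`) has not yet been measured. It differs from compound 3 by hydrogen in place of chloro on an aromatic carbon, the same kind of change as that between compound 1 and compound 2. Among the measured compounds shown here, because that step is a step that the two limits leave unreadable from compound 1 to compound 2, it gives no guidance on size or direction, and no other measured step bears on this change. Compound 4 is therefore expected to give about 10000 nM in this assay, within a range from 3000 nM to 40000 nM. This corresponds to an expected step of a 1.6-fold higher number from compound 3 to compound 4 (0.19 log units; within the scatter), which may well prove no larger than the scatter.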

Compound 4, half-maximal inhibitory concentration: 3800 nM
The estimate for compound 4 lay 2.6-fold (0.42 log units) above the measured number, and the stated range covers the measured number.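

In this assay, hydrogen in place of chloro gives a 1.7-fold lower number from compound 3 to compound 4 (0.23 log units; within the scatter), the first readable size for this change. On this aromatic carbon of the core of compound 3, the pair therefore shows no effect of removing the chloro that can be told apart from ordinary repeat-to-repeat variation. The same change between compound 1 and compound 2 cannot be read, as both values are limits of the assay rather than numbers: the limit of > 25000 nM in this assay, at which 2 of the 4 values shown sit.

Only chloro and hydrogen are shown at this position, so it remains open whether another group there, such as a methoxy, an amine or a carboxylic acid, would move the number beyond the scatter. Going by these compounds, it also remains open whether this change has a readable effect on the core of compound 1.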